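Swapping 4-(dimethylamino)phenyl for 2-chlorophenyl

The source may report more compounds than this note shows. Statements on the series, on what has been measured and on what is new or still open speak of the compounds shown alone.

In a functional assay, read by spectrophotometry, tested at 100 uM (a higher number here means a weaker inhibitor, a lower number a stronger inhibitor), compound 1 `Cc1ccc(/C=C/C(=O)c2cccc(NC(=O)c3cc(-c4ccncc4)n[nH]3)c2)cc1` gives 64600 nM and compound 2 `CN(C)c1ccc(/C=C/C(=O)c2cccc(NC(=O)c3cc(-c4ccncc4)n[nH]3)c2)cc1` gives 60900 nM, so compound 2 stands level with compound 1 within the scatter. Compound 3 `O=C(/C=C/c1ccccc1Cl)c1cccc(NC(=O)c2cc(-c3ccncc3)n[nH]2)c1` departs from compound 2 by 2-chlorophenyl in place of 4-(dimethylamino)phenyl on a double-bonded chain carbon bound to a double-bonded chain carbon, with 2-chlorophenyl in place of 4-(dimethylamino)phenyl on a double-bonded chain carbon bound to a double-bonded chain carbon. For the measured compounds named here, only one measured step bears on this: a 1.1-fold lower number from compound 1 to compound 2 (0.03 log units; within the scatter), with dimethylamino in place of methyl. Going by the values given here, no measured compound carries chlorine, so no step beyond the scatter is expected in this assay. The expected change is a 1.1-fold lower number from compound 2 to compound 3 (0.04 log units; within the scatter). Compound 3 is estimated at 55000 nM, within a range of 20000 nM to 100000 nM.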

Compound 3, half-maximal inhibitory concentration: 79800 nM
Estimate against measurement, compound 3: 1.5-fold (0.16 log units) below; low and high end bracket the measured number.
By their numbers in this assay, from the lowest: compounds 2, 1 and 3 (each within the scatter of the next).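

In this assay, 2-chlorophenyl brings chlorine to the place on a double-bonded chain carbon bound to a double-bonded chain carbon, yet the change gives a 1.3-fold higher number from compound 2 to compound 3 (0.12 log units; within the scatter) and a 1.2-fold higher number from compound 1 to compound 3 (0.09 log units; within the scatter). Three different phenyl groups at this place, 4-methylphenyl, 4-(dimethylamino)phenyl and 2-chlorophenyl, therefore stand level within the scatter. Nothing at hand accounts for this.

From the compounds shown here alone, whether a carboxylic acid on the phenyl ring would give a step beyond the scatter remains open. The same holds for a longer alkyl chain in place of the phenyl ring.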